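The source may report more compounds than this note shows. Statements on the series, on what has been measured and on what is new or still open speak of the compounds shown alone.

Measured so far:
Compound 1, `Clc1ccc(COc2ccc(/C=C/C(/C=C/c3ccccn3)=N/Oc3ncnc4ccccc34)cc2)cc1`: 94.4%
Compound 2, `Clc1ccc(COc2ccc(/C=C/C(/C=C/c3ccccn3)=N/Oc3ncnc4cc(Cl)ccc34)cc2)cc1`: 88.1%
Compound 3, `Cc1cccc2ncnc(O/N=C(\C=C\c3ccccn3)/C=C/c3ccccc3OCc3ccccc3Cl)c12`: 95.7%

These three compounds were tested in a functional assay on SMMC-7721 cells (Homo sapiens) for inhibition, read by MTT assay, with a stated time of 72 h, tested at 10 uM; a higher number here means a stronger effect of the compound at the concentration tested, a lower number a weaker effect. Compound 1 gives 94.4%, and compound 2 gives 88.1%; compound 3 gives 95.7%. The three numbers lie within the scatter of one another, so none of them can be set apart from the others.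

Compound 2 differs from compound 1 by one change, (chloro in place of hydrogen on an aromatic carbon), and the step is a number 6.3 percentage points lower from compound 1 to compound 2 (within the scatter). Compound 3 shares much with compound 1, but the difference between the two cores is not broken down here.

Compound 4, `Cc1cccc2ncnc(O/N=C(\C=C\c3ccccn3)/C=C/c3ccccc3OCc3ccc(Cl)cc3Cl)c12`, has not yet been measured in this assay. It differs from compound 3 by chloro in place of hydrogen on an aromatic carbon. This is the same kind of change as that from compound 1 to compound 2, but the place differs: in compound 2 the chloro sits on a ring that is part of a fused system of two rings, meta and para to the fused ring, whereas in compound 4 it sits on a ring of carbon only, meta to a chloro group and para to a large group. Because the earlier step of a number 6.3 percentage points lower from compound 1 to compound 2 (within the scatter) stayed within the scatter, the step from compound 3 to compound 4 is expected to be small, a number 5.7 percentage points lower from compound 3 to compound 4 (within the scatter). For compound 4 the estimate in this assay is 90%, with a range from 80% to 97%.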

Compound 4, a percentage reported as inhibition, at one concentration (the size of the read-out at that concentration, not a potency): 93.9%
The estimate for compound 4 lay 3.9 percentage points below the measured number, and the stated range covers the measured number.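

In this assay, the step of a number 1.8 percentage points lower from compound 3 to compound 4 (within the scatter) is a second case of chloro in place of hydrogen on an aromatic carbon, and it can be set beside the earlier step on the other core: the same change on two cores in this assay, a number 6.3 percentage points lower (within the scatter) from compound 1 to compound 2 and a number 1.8 percentage points lower (within the scatter) from compound 3 to compound 4, 4.5 percentage points apart, within the scatter of two such steps. In these two pairs, then, the change leaves the read-out within the scatter on both cores, and the two steps cannot be told apart. Among these compounds, this does not show that the change carries over in general: there are only two pairs, the chloro stands at a different place in each, so core and place cannot be separated, and a single concentration gives the size of the read-out and not a potency.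

The compounds shown leave open whether a fluoro, a methoxy or an amine at the same place as the new chloro would also stay within the scatter. They also leave open what a carboxylic acid or a longer chain on the 2,4-dichlorobenzyl group would do in this assay.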